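Turning one ring stereocentre of compound 2

The source may report more compounds than this note shows. Statements on the series, on what has been measured and on what is new or still open speak of the compounds shown alone.

The series rests on two measured stereoisomers of the same core. Compound 1 `O=C(O)[C@H]1NC[C@@H](O)[C@H](O)[C@H]1O` and compound 2 `O=C(O)[C@H]1NC[C@H](O)[C@H](O)[C@@H]1O` share every atom and bond and differ only in configuration as drawn. In an assay on isolated protein for inhibition of cytosolic endo-beta-N-acetylglucosaminidase (Homo sapiens), tested at 1000 uM (a lower number here means less inhibition, a higher number more inhibition at the concentration tested (going by the name of the read-out)), compound 1 gives 6.3%, while compound 2 gives 26%, and the step of a number 19.7 percentage points higher from compound 1 to compound 2 (beyond the scatter) rests on (the fact that compounds 1 and 2 differ only in the configuration as drawn). On the numbers shown, compound 2 stands highest of the two. Compound 3 `O=C(O)[C@H]1NC[C@H](O)[C@H](O)[C@H]1O` is the next isomer: the two compounds have the same atoms and bonds and differ only in configuration as drawn: 1 of 4 stereo elements differ; a stereocentre at a saturated ring carbon is drawn R in compound 2 and S in compound 3. Within the data shown here, only one measured step bears on this change, and it covered two stereo elements rather than one, so the account treats it as a loose guide. A single inversion of a ring stereocentre is expected to shift the read-out by a modest amount, most likely downward, so the step of a number 11 percentage points lower from compound 2 to compound 3 (beyond the scatter) is the estimated change. For compound 3 the expected value in this assay is 15%, within a range from 2% to 40%.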

Compound 3, a percentage reported as inhibition, at one concentration (the size of the read-out at that concentration, not a potency): 7.6%
For compound 3 the middle estimate is 7.4 percentage points above the measured one; low and high end bracket the measured number.
By their numbers in this assay, from the lowest: compounds 1 and 3 (each within the scatter of the next); then compound 2.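

In this assay the step of a number 18.4 percentage points lower from compound 2 to compound 3 (beyond the scatter) shows that a single inverted stereocentre can carry a clear change, whereas the earlier pair had two stereo elements changing together and could not assign its step to either one. The other single inversion gives a number 1.3 percentage points higher from compound 1 to compound 3 (within the scatter) and so separates nothing, which leaves compound 2 alone standing apart among these three stereoisomers. The comparison with compound 2 isolates one configurational change and nothing else: the fact that compounds 2 and 3 differ only in the configuration as drawn.

Going by these compounds, whether the configuration of compound 2 would keep its read-out with a methyl ester or an amide in place of the carboxylic acid, or with an amine in place of a hydroxyl, stays open. The read-out also comes from one concentration, so these numbers give no potency for any of the three compounds.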